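The source may hold more compounds than are shown below. What is called first, only, known or untested is meant among the compounds shown, and "the series" means these compounds.

Measured in an ADME assay on HepG2 2.2.15 cells (Homo sapiens) for cytotoxicity, read by MTT assay; a higher number here means that more compound is tolerated, a lower number that less compound is tolerated:
- Compound 1 `COc1cc(/C=C/C(=O)Oc2ccc(C(C)=O)cc2)cc(OC)c1OC`: > 2420000 nM
- Compound 2 `CC(=O)c1ccc(O[C@@H]2O[C@H](COC(=O)/C=C/c3cccc(F)c3)[C@@H](O)[C@H](O)[C@H]2O)cc1`: 828000 nM
- Compound 3 `COc1cc(C(=O)OC[C@H]2O[C@@H](Oc3ccc(C(C)=O)cc3)[C@H](O)[C@@H](O)[C@@H]2O)cc(OC)c1OC`: 890000 nM

The value of compound 1, > 2420000 nM, is a limit of the assay and not a number, so it cannot be placed exactly beside the other two. Compound 2 at 828000 nM and compound 3 at 890000 nM lie within the usual scatter of repeated measurements, so these two results cannot be told apart.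

The next compound to follow is compound 4 `CC(=O)c1ccc(O[C@@H]2O[C@H](COC(=O)c3cccs3)[C@@H](O)[C@H](O)[C@H]2O)cc1`. It is compound 2 with thiophen-2-yl in place of 2-(3-fluorophenyl)ethenyl on a carbonyl carbon. The swap removes the double bond outside the rings and brings in a smaller ring that holds sulfur.

Among the compounds with values here, no measured pair here differs in one place only, so the expectation rests on thin ground. With compound 2 at 828000 nM and compound 3 at 890000 nM so close together, no step beyond the scatter is expected in this assay, in either direction. The expected step is a 1.1-fold higher number from compound 2 to compound 4 (0.04 log units; within the scatter). For compound 4 the estimate is 900000 nM, with an expected range of 400000 nM to 2000000 nM.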

Compound 4, half-maximal cytotoxic concentration: 1570000 nM
Compound 4: middle estimate off by 1.7-fold (0.24 log units), on the low side, within the range that was stated.
By their numbers in this assay, from the lowest: compounds 2, 3 and 4 (each within the scatter of the next). At a limit, above all of these: compound 1.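

Within the data shown here, this is the first step here between two compounds that differ in one place only, and it gives a direct reading at this position. In this assay, putting thiophen-2-yl in place of 2-(3-fluorophenyl)ethenyl on a carbonyl carbon gives a 1.9-fold higher number from compound 2 to compound 4 (0.28 log units; within the scatter), so the swap cannot be told apart from no change at all. A smaller group holding sulfur, with no fluorine and no double bond outside the ring, can therefore take this place without a measurable difference in how much compound the cells tolerate, though one value shown is a limit of the assay and not a number: the limit of > 2420000 nM in this assay, at which 1 of the 4 values shown sits.

Fluorine and the double bond leave together in this step, and what each contributes alone remains unknown. As far as these compounds go, it is also open whether a group of a different kind on this carbonyl carbon, such as a chain ending in an amine or a carboxylic acid, would give a step beyond the scatter.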